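Aryl swap on the amine nitrogen: compound 3 to compound 4

The source may hold more compounds than are shown below. What is called first, only, known or untested is meant among the compounds shown, and "the series" means these compounds.

In a functional assay on HeLa cells (Homo sapiens) for inhibition, read by sulforhodamine B assay (a higher number here means a weaker inhibitor, a lower number a stronger inhibitor), compound 3 `COc1ccccc1NC1=CC(=O)c2c(nc3n2[C@H]2OC[C@@H](O)[C@H]2OC3)C1=O` gives 7460 nM. Compound 2 `Cc1ccc(NC2=CC(=O)c3c(nc4n3[C@H]3OC[C@@H](O)[C@H]3OC4)C2=O)cc1C` gives 4320 nM, and the measured step is a 1.7-fold higher number from compound 2 to compound 3 (0.24 log units; within the scatter). Compound 1 `O=C1C(Nc2ccccc2)=CC(=O)c2c1nc1n2[C@H]2OC[C@@H](O)[C@H]2OC1` gives only a limit, > 8000 nM.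

Compound 4 `O=C1C(Nc2ccc(C(F)(F)F)cc2)=CC(=O)c2c1nc1n2[C@H]2OC[C@@H](O)[C@H]2OC1` has 4-(trifluoromethyl)phenyl in place of 2-methoxyphenyl on the amine nitrogen: 4-(trifluoromethyl)phenyl in place of 2-methoxyphenyl on an amine nitrogen.

The relevant aryl changes are an at least 1.8-fold lower number from compound 1 to compound 2 (0.26 log units; that floor lies within the scatter) and an at least 1.0-fold lower number from compound 1 to compound 3 (0.03 log units; that floor lies within the scatter). Together with the step above, neither shows a change beyond the scatter, so no step beyond the scatter is expected here. The expected step is a 1.2-fold lower number from compound 3 to compound 4 (0.09 log units; within the scatter). The estimate for compound 4 is 6000 nM, with an expected range of 2500 nM to 13000 nM.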

Compound 4, half-maximal inhibitory concentration: 8920 nM
Beside the measured number, compound 4's estimate is 1.5-fold (0.17 log units) below it; the measured number falls inside the stated range.
By their numbers in this assay, from the lowest: compounds 2, 3 and 4 (each within the scatter of the next, the first and the last beyond it).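

Among the compounds shown here, on the amine nitrogen, 4-(trifluoromethyl)phenyl gives the only readable aryl swap beyond the scatter in this assay: a 2.1-fold higher number from compound 2 to compound 4 (0.31 log units; beyond the scatter), with 4-(trifluoromethyl)phenyl in place of 3,4-dimethylphenyl. In place of 2-methoxyphenyl, the same group leaves the number within the scatter, with a 1.2-fold higher number from compound 3 to compound 4 (0.08 log units; within the scatter). The step from compound 1 to compound 4 cannot be read, because compound 1 carries a limit: the limit of > 8000 nM in this assay, at which 1 of the 4 values shown sits.

Going by these compounds, whether a basic amine, a carboxylic acid or a pyridine ring at this nitrogen would lower the number remains open. The compounds shown also leave open how a single substituent's ring position affects the number.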